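This account rests on a few compounds, and the source may have more. Where it says the series, first, only, none or still open, it means among the compounds named here.

Measured so far in a functional assay on HepG2 cells (Homo sapiens) for inhibition, read by MTT assay, with a stated time of 24 h; on this read-out higher numbers stand for weaker inhibition and lower numbers for stronger inhibition:

Compound 1 `COc1ccc(-n2cc(CN3C(=O)C[C@@H]4CC[C@@]3(C)C4(C)C)nn2)cc1` — 100 nM
Compound 2 `CC1(C)[C@H]2CC[C@]1(C)N(Cc1cn(-c3ccccc3C#N)nn1)C(=O)C2` — 180 nM
Compound 3 `CC1(C)[C@H]2CC[C@]1(C)N(Cc1cn(-c3ccccc3Cl)nn1)C(=O)C2` — 60 nM

Compound 3 gives the lowest of the three numbers, but only the gap to compound 2 is clear: a 3.0-fold lower number from compound 2 to compound 3 (0.48 log units; beyond the scatter), whereas a 1.7-fold lower number from compound 1 to compound 3 (0.22 log units; within the scatter), so compound 1 and compound 3 cannot be separated on these numbers.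

Compound 4 `Cc1cccc(-n2cc(CN3C(=O)C[C@@H]4CC[C@@]3(C)C4(C)C)nn2)c1` is the next member of the series. Change: 3-methylphenyl in place of 2-chlorophenyl on an aromatic nitrogen.

All three measured steps concern the group on this aromatic nitrogen, so all bear on the question. Swapping the aryl group has moved this assay only modestly so far: a 1.8-fold higher number from compound 1 to compound 2 (0.26 log units; within the scatter), a 1.7-fold lower number from compound 1 to compound 3 (0.22 log units; within the scatter), and at most a 3.0-fold lower number from compound 2 to compound 3 (0.48 log units; beyond the scatter). Going by the values given here, no measured pair exchanges 2-chlorophenyl for 3-methylphenyl directly, so the direction is uncertain; the expected step is small, a 1.7-fold higher number from compound 3 to compound 4 (0.22 log units; within the scatter), most likely within the scatter. Compound 4 is therefore expected to give about 100 nM in this assay, with a range from 45 nM to 230 nM.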

Compound 4, half-maximal inhibitory concentration: 300 nM
The estimate for compound 4 lay 3.0-fold (0.48 log units) below the measured number; the measured number lies above the stated range.
By their numbers in this assay, from the lowest: compounds 3, 1, 2 and 4 (each within the scatter of the next, the first and the last beyond it).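

In this assay, going by these compounds alone, the aryl group on this aromatic nitrogen now shows a wider spread than the earlier compounds did: the change from 2-chlorophenyl to 3-methylphenyl gives a 5.0-fold higher number from compound 3 to compound 4 (0.70 log units; beyond the scatter) and is the largest step so far. The change from 4-methoxyphenyl to 3-methylphenyl also lies beyond the scatter, with a 3.0-fold higher number from compound 1 to compound 4 (0.48 log units; beyond the scatter) as its size, whereas a 1.7-fold higher number from compound 2 to compound 4 (0.22 log units; within the scatter) leaves 2-cyanophenyl and 3-methylphenyl inseparable, so a substituent need not be chloro or methoxy for the numbers to differ, and these two cannot be ranked. No evidence at hand accounts for these steps.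

Going by these compounds, compound 3 and compound 4 differ in both the substituent and its place on the phenyl ring, so which of the two carries the step remains open. The 2-methylphenyl and 3-chlorophenyl groups would separate the two, and the unsubstituted phenyl group would give a common reference.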